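The compounds below may be only part of what the source reports. "The series", "measured", "known", "first", "only" and "open" are said of these compounds alone.

Measured compounds in a functional assay on HeLa cells (Homo sapiens) for cytotoxicity, read by MTT assay, with a stated time of 72 h; on this read-out lower numbers stand for stronger inhibition and higher numbers for weaker inhibition:

Compound 1, `Cc1cccc(/C(N)=N/NC(=S)N2CCCCC2)n1`, gives 2000 nM.
Compound 2, `N/C(=N\NC(=S)N1CCN(c2ccccn2)CC1)c1ccc(F)cn1`, gives 2000 nM.
Compound 3, `Cc1ccnc(/C(N)=N/NC(=S)N2CCCCC2)c1`, gives 7700 nM.

Compound 2 stands level with compound 1 at the digits shown; the two numbers lie within the usual scatter of this assay, so no order between them can be read. Compound 3 gives a higher number than compound 2, and that gap lies beyond the scatter, so compounds 1 and 2 together give the lowest numbers of the three.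

Compound 4, `N/C(=N\NC(=S)N1CCN(c2ccccn2)CC1)c1ccccn1`, has not yet been measured. It differs from compound 2 in one place: hydrogen in place of fluoro on an aromatic carbon. For the measured compounds named here, no pair of measured compounds here shows the effect of this same change, so nothing in the data shows how a hydrogen in place of fluoro on an aromatic carbon moves the number. The removal of a single fluorine is a small change, and in the absence of any comparable step the expectation is that compound 4 stays close to compound 2, with no step beyond the scatter in either direction. The step from compound 2 to compound 4 is expected to be a 1.3-fold higher number from compound 2 to compound 4 (0.10 log units; within the scatter). For compound 4 the estimate is 2500 nM, with a range from 1000 nM to 6000 nM.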

Compound 4, half-maximal inhibitory concentration: 8600 nM
Beside the measured number, compound 4's estimate is 3.4-fold (0.54 log units) below it, and the stated range ends below it.
By their numbers in this assay, from the lowest: compounds 1 and 2 (each within the scatter of the next); then compounds 3 and 4 (each within the scatter of the next).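

For the compounds shown here, this is the first pair that isolates a single change: in this assay, going from 5-fluoropyridin-2-yl to pyridin-2-yl gives a 4.3-fold higher number from compound 2 to compound 4 (0.63 log units; beyond the scatter). The fluoro therefore counts at this position, on an aromatic carbon two atoms from the ring nitrogen and para to a large group, since replacing this one heavy atom with hydrogen moves the number beyond the scatter, with higher numbers standing for weaker inhibition. Nothing available here accounts for the size or direction of the step, which stands as an observation on this one pair.

Going by these compounds, whether a chlorine, a methyl group or a methoxy group on the same carbon would keep the number level with that of compound 2 remains open, so it cannot be said whether the effect is particular to fluoro or shared by other groups. On these data alone, it also remains open whether hydrogen in place of fluoro would move the number by a similar step on the core of compound 1.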